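Replacing bromo with dimethylamino in compound 1

A few compounds are considered here, and "the series" means these few. Any claim that something is new, unique, unknown or untested is made for them only; others in the source may bear on it.

In a functional assay on DU-145 cells (Homo sapiens) for inhibition, read by trypan blue exclusion, with a stated time of 96 h (on this read-out higher numbers stand for weaker inhibition of growth and lower numbers for stronger inhibition of growth), compound 1 (`Cc1ccc(CS(=O)(=O)/C(=C/c2ccc(Br)cc2)C(=O)c2ccc(Cl)cc2)cc1`) gives 25000 nM. Compound 3 (`CN(C)c1ccc(/C=C(/SCc2ccc(Br)cc2)C(=O)c2ccc(C(=O)O)cc2)cc1`) gives 50000 nM, a number within the scatter of that of compound 1. Compound 2 (`Cc1cc(C)cc(/C=C(\C(=O)c2ccc(Cl)cc2)S(=O)(=O)Cc2ccc(Cl)cc2)c1`) gives 1000 nM, a number lower than that of compound 1 by well beyond the scatter, so compound 1 stands far from the strongest inhibition of growth seen here.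

Compound 4 (`Cc1ccc(CS(=O)(=O)/C(=C/c2ccc(N(C)C)cc2)C(=O)c2ccc(Cl)cc2)cc1`) has not yet been measured. It differs from compound 1 in one place: dimethylamino in place of bromo on an aromatic carbon. This puts dimethylamino in place of bromo on an aromatic carbon, para to a large group. Going by the values given here, no measured pair isolates this change. Compound 4 shares the 4-(dimethylamino)phenyl group with compound 3, which gives 50000 nM, but the two differ elsewhere, so that value is only a weak guide. A small step toward a lower number is expected in this assay, and the estimate is a 2.5-fold lower number from compound 1 to compound 4 (0.40 log units; beyond the scatter). For compound 4 the expected value is 10000 nM, with an estimated range of 2000 nM to 50000 nM.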

Compound 4, concentration for 50% growth inhibition: 50000 nM
For compound 4 the middle estimate is 5.0-fold (0.70 log units) below the measured one; low and high end bracket the measured number.
By their numbers in this assay, from the lowest: compound 2; then compounds 1, 3 and 4 (each within the scatter of the next).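

In this assay, the exchange of bromo for dimethylamino gives a 2.0-fold higher number from compound 1 to compound 4 (0.30 log units; within the scatter) and so the two compounds cannot be told apart. This single pair shows that, on this aromatic carbon, para to a large group, one heavy atom of bromo can give way to the three heavy atoms and one hydrogen-bond acceptor of dimethylamino without a step beyond the scatter. No measurement at hand offers a reason for this outcome.

On these data alone, whether a primary amine, a methoxy group or a fluoro at the same place would also stay within the scatter of compound 1 remains open. So does whether the same exchange would give a similar step on another core, as this pair is its only reading.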